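A few compounds are considered here, and "the series" means these few. Any claim that something is new, unique, unknown or untested is made for them only; others in the source may bear on it.

Series notes, solubility at physiological pH. Compound 3 `CC(C)Nc1nc(NC2CCCCC2)c2ccccc2n1` stands in a physicochemical assay for solubility, at pH 7.4 (on this read-out higher numbers stand for higher solubility and lower numbers for lower solubility), only at a limit of the assay, <= 20000 nM. Compound 1 `CC(C)Nc1nc(NCc2ccco2)c2ccccc2n1` is likewise reported in this assay at a limit, >= 30000 nM. Compound 2 `CSCCNc1nc(NC(C)C)nc2ccccc12` also returns a limit in this assay, <= 20000 nM. For the measured compounds named here, no member of the set carries a read number; the three values split between the limit of <= 20000 nM in this assay, at which 2 of the 3 values shown sit, and (the limit of >= 30000 nM in this assay, at which 1 of the 3 values shown sits). The step from compound 1 to compound 3 reads an at least 1.5-fold lower number from compound 1 to compound 3 (0.17 log units; that floor lies within the scatter), the step from compound 1 to compound 2 reads an at least 1.5-fold lower number from compound 1 to compound 2 (0.17 log units; that floor lies within the scatter), and the step from compound 2 to compound 3 is a step that the two limits leave unreadable from compound 2 to compound 3.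

Compound 4 `CC(C)Nc1nc(N(C)C)c2ccccc2n1` differs from compound 3 in one place: dimethylamino in place of cyclohexylamino on an aromatic carbon. Going by the values given here, the measured steps that touch this position exchange one ring-bearing or chain-bearing group with a donor for another; none introduces a group with no ring and no donor, so no measured step bears directly on this change. With compound 3 itself at a limit, neither the size nor the direction of the step can be read from the numbers in hand. Compound 4 is therefore expected, as an estimate only, at 25000 nM within a wide range of 10000 nM to 60000 nM, corresponding to an estimated step of an at least 1.2-fold higher number from compound 3 to compound 4 (0.09 log units; that floor lies within the scatter).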

Compound 4, solubility: <= 10000 nM
Compound 4 was reported as a limit (the forecaster's own chance of this, stated with the estimate: 60%); middle value at least 2.5-fold (0.39 log units) from the limit.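

Within this assay, the change at this position now has one readable size: dimethylamino in place of ((furan-2-yl)methyl)amino on an aromatic carbon gives an at least 3.0-fold lower number from compound 1 to compound 4 (0.47 log units; beyond the scatter). Unlike the two earlier readable steps, whose floors lie within the scatter, this floor lies beyond it, so a group with no ring and no hydrogen-bond donor at this position stands apart from the (furan-2-yl)methyl group by a readable margin. Compound 4 also carries a limit that no other compound shown shares: the limit of <= 10000 nM in this assay, at which 1 of the 4 values shown sits.

The steps to compound 4 from compound 2 and from compound 3 cannot be read, as both ends of each are limits, so dimethylamino, cyclohexylamino and (2-(methylsulfanyl)ethyl)amino remain unordered among themselves. On these data alone, whether the readable step follows the loss of the furan ring, the loss of the amine hydrogen or the smaller size of the group also stays open, and a methylamino group or a morpholine at this position would be needed to separate the loss of the donor from the loss of the ring.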